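Replacing an aryl with a cyclohexyl on a lactam nitrogen

This account rests on a few compounds, and the source may have more. Where it says the series, first, only, none or still open, it means among the compounds named here.

Compound 1 `O=C1COc2ccc(-c3cnc(Cl)c(NS(=O)(=O)c4ccc(F)cc4)c3)cc2N1C1CCCCC1`: in a functional assay on HCT-116 cells (Homo sapiens) for antiproliferative activity, read by MTT assay, with a stated time of 72 h (a higher number here means a weaker inhibitor, a lower number a stronger inhibitor), compound 1 gives > 40000 nM, which is a limit of the assay and not a number.
Compound 2 `COc1ccc(N2C(=O)COc3ccc(-c4cnc(Cl)c(NS(=O)(=O)c5ccc(F)cc5)c4)cc32)cc1`: in this assay compound 2 gives 30100 nM.
Compound 3 `COc1ccc(N2C(=O)COc3ccc(-c4cccc(NS(=O)(=O)c5ccc(F)cc5)c4)cc32)cc1`: in this assay compound 3 gives 28300 nM.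

Three compounds share a sulfonamide-bearing aryl group attached to a fused bicyclic lactam, and they differ in the group on the amide-type nitrogen in a ring and in the aromatic ring that carries the sulfonamide. The step from compound 2 to compound 1 is cyclohexyl in place of 4-methoxyphenyl on an amide-type nitrogen in a ring and gave an at least 1.3-fold higher number from compound 2 to compound 1 (0.12 log units; that floor lies within the scatter). Its size is bounded by the limit of > 40000 nM in this assay, at which 1 of the 3 values shown sits. The difference between the cores of compound 2 and compound 3 is not broken down here; their two values sit close together.

Compound 4 `O=C1COc2ccc(-c3cccc(NS(=O)(=O)c4ccc(F)cc4)c3)cc2N1C1CCCCC1` has not yet been measured in this assay. It differs from compound 3 by cyclohexyl in place of 4-methoxyphenyl on an amide-type nitrogen in a ring, the same kind of change as that from compound 2 to compound 1. Since the earlier step ran upward from the value of compound 2, and compound 3 gives 28300 nM, the expected step of a 1.6-fold higher number from compound 3 to compound 4 (0.20 log units; within the scatter) is set near the earlier one. Compound 4 is therefore estimated at 45000 nM, with a range from 25000 nM to 100000 nM, and a limit rather than a number is considered likely.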

Compound 4, half-maximal inhibitory concentration: 18300 nM
Estimate against measurement, compound 4: 2.5-fold (0.39 log units) above; measured number outside the range, below it.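

In this assay, putting cyclohexyl in place of 4-methoxyphenyl on the amide-type nitrogen in a ring gave a 1.5-fold lower number from compound 3 to compound 4 (0.19 log units; within the scatter), so on this core the change leaves the number within the usual scatter of repeated measurements. This shows that the change had no effect on this core that can be told from that scatter, but it does not show whether the change behaves alike or differently on the two cores: the same change on two cores in this assay, an at least 1.3-fold higher number (0.12 log units; that floor lies within the scatter) from compound 2 to compound 1 and a 1.5-fold lower number (0.19 log units; within the scatter) from compound 3 to compound 4; the limit leaves it open whether they differ The value of compound 1 is a limit of the assay and not a number, so the earlier step has only a floor and no size of its own, and the comparison between the two cores stays unsettled for that reason: the limit of > 40000 nM in this assay, at which 1 of the 4 values shown sits.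

The compounds shown leave open how this assay would read with other groups on the amide-type nitrogen, such as a methyl, a benzyl or a chain ending in an amine. They also leave open whether a nitrile or a methoxy in place of the fluorine on the sulfonamide side would move the number beyond the scatter on either core.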